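This account rests on a few compounds, and the source may have more. Where it says the series, first, only, none or still open, it means among the compounds named here.

Three compounds share one core and differ in the aromatic group carried on a saturated chain that runs from an oxygen next to a carbonyl group. In an assay on CHO cells for displacement of a labelled ligand from muscarinic acetylcholine receptor M5 (Homo sapiens), read by scintillation counting, with a stated time of 2 h (on this read-out higher numbers stand for weaker inhibition and lower numbers for stronger inhibition), compound 1 `O=C(OCCc1ccc(Cl)c(Cl)c1)N(c1ccccc1)C1CN2CCC1CC2` gives 80 nM, compound 2 `O=C(OCc1ccc(Cl)c(Cl)c1)N(c1ccccc1)C1CN2CCC1CC2` gives 60 nM, and compound 3 `Cc1ccc(CCCOC(=O)N(c2ccccc2)C2CN3CCC2CC3)cc1F` gives 130 nM. Compound 3 holds the highest of the three numbers, though its gap to compound 1 lies within the scatter and only its gap to compound 2 lies beyond it. Compound 4 `COc1ccc(CCCOC(=O)N(c2ccccc2)C2CN3CCC2CC3)cc1OC` carries 3,4-dimethoxyphenyl in place of 3-fluoro-4-methylphenyl on a saturated chain carbon, three bonds along the chain from an oxygen next to a carbonyl group. The two steps that bear on this change, a 1.6-fold higher number from compound 1 to compound 3 (0.21 log units; within the scatter) and a 1.3-fold lower number from compound 1 to compound 2 (0.12 log units; within the scatter), each altered the aromatic group or its chain without leaving the scatter, so a step of no more than the scatter is expected here, a 1.2-fold higher number from compound 3 to compound 4 (0.06 log units; within the scatter). Compound 4 is therefore estimated at 150 nM, within a range from 60 nM to 400 nM.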

Compound 4, inhibition constant: 1610 nM
The estimate for compound 4 lay 11-fold (1.03 log units) below the measured number, outside the stated range (above it).
By their numbers in this assay, from the lowest: compounds 2, 1 and 3 (each within the scatter of the next, the first and the last beyond it); then compound 4.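

Replacing 3-fluoro-4-methylphenyl with 3,4-dimethoxyphenyl on this chain gives a 12-fold higher number from compound 3 to compound 4 (1.09 log units; beyond the scatter). The earlier steps shown here among the aromatic groups and their chains all stayed within the scatter, so this position is less tolerant than they suggested: here, the groups on the aromatic ring can matter greatly. Nothing available accounts for the size of this step. The compounds shown leave open whether a single methoxy group on the ring would weaken inhibition as much as two, and how a hydroxyl group there would behave.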